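A few compounds are considered here, and "the series" means these few. Any claim that something is new, unique, unknown or untested is made for them only; others in the source may bear on it.

Compound 2 `O=C1Cc2cc(S(=O)(=O)N3CCN(c4ccc([N+](=O)[O-])cc4)CC3)ccc2N1` gives 3260 nM in an assay on isolated protein for inhibition of lysosomal alpha-glucosidase (Homo sapiens), read by fluorescence, with stated times of 5 min and 45 min; on this read-out higher numbers stand for weaker inhibition and lower numbers for stronger inhibition. Going by the values given here, on the numbers so far it stands highest of two, with its nearest neighbour, compound 1 `O=C1Cc2cc(S(=O)(=O)N3CCN(c4ccc(O)cc4)CC3)ccc2N1`, giving 2370 nM in this assay, a gap that lies within the scatter. A third member of the set, compound 3 `O=C1Cc2cc(S(=O)(=O)N3CCN(c4ccc(F)cc4)CC3)ccc2N1`, is reported in this assay as "not active" (no number reported), with no number attached. Compound 4 `O=C1Cc2cc(S(=O)(=O)N3CCN(c4ccc(C(F)(F)F)cc4)CC3)ccc2N1` has not yet been measured. It differs from compound 2 by trifluoromethyl in place of nitro on an aromatic carbon. Among the compounds with values here, only one measured step bears on this change, and it was a 1.4-fold higher number from compound 1 to compound 2 (0.14 log units; within the scatter); compound 3, with its own single change from compound 1, yielded no number at all. Taken together these give little ground for expecting a step beyond the scatter in either direction for compound 4, though the outcome for compound 3 leaves open that no number may be obtained here either. Compound 4 is therefore estimated at 5000 nM, with a range from 1500 nM to 20000 nM, which amounts to an expected step of a 1.5-fold higher number from compound 2 to compound 4 (0.19 log units; within the scatter).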

Compound 4, half-maximal inhibitory concentration: "not active" (no number reported)
The entry for compound 4 holds no number, so the estimate cannot be set against anything.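

Going by these compounds alone, compound 4 is reported in this assay as "not active", with no number, so no step from compound 2 to compound 4 can be read. Nothing shown here accounts for this result. The compounds shown leave open how compound 3 and compound 4 compare with each other.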